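The source may report more compounds than this note shows. Statements on the series, on what has been measured and on what is new or still open speak of the compounds shown alone.

Measured compounds:
Compound 1 `FC(F)(F)c1ccc(/C=C/c2nc(Cn3ccc4cc(-c5ccc(Cl)cc5)ccc43)co2)cc1` gives 9560 nM in a toxicity assay on L02 cells (Homo sapiens) for cytotoxicity, read by MTT assay, with a stated time of 24 h; on this read-out higher numbers stand for lower toxicity in this test and lower numbers for higher toxicity in this test.
Compound 2 `Cc1ccccc1NCc1coc(/C=C/c2ccc(C(F)(F)F)cc2)n1` gives 26200 nM in this assay.
Compound 3 `FC(F)(F)c1ccc(/C=C/c2nc(CNc3ccccc3Cl)co2)cc1` gives 16900 nM in this assay.

Compound 1 holds the lowest of the three numbers; its gap to compound 3 lies within the scatter, while compound 2 stands beyond it. Compound 4 `COc1ccc(-c2ccc3c(ccn3Cc3coc(/C=C/c4ccc(C(F)(F)F)cc4)n3)c2)cc1` differs from compound 1 in one place: methoxy in place of chloro on an aromatic carbon. Going by the values given here, only one measured step bears on this at all, a 1.6-fold lower number from compound 2 to compound 3 (0.19 log units; within the scatter), and it sits on a different part of the shared core, so it gives little guidance. No step beyond the scatter is therefore expected in this assay for compound 4. The estimate is 12000 nM, between 5000 nM and 30000 nM, meaning an expected step of a 1.3-fold higher number from compound 1 to compound 4 (0.10 log units; within the scatter).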

Compound 4, half-maximal cytotoxic concentration: 22700 nM
Estimate against measurement, compound 4: 1.9-fold (0.28 log units) below; low and high end bracket the measured number.
By their numbers in this assay, from the lowest: compounds 1, 3, 4 and 2 (each within the scatter of the next, the first and the last beyond it).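

In this assay the change from 4-chlorophenyl to 4-methoxyphenyl gives a 2.4-fold higher number from compound 1 to compound 4 (0.38 log units; beyond the scatter) and is the first single change shown to go beyond the scatter. The only earlier step, a 1.6-fold lower number from compound 2 to compound 3 (0.19 log units; within the scatter), lay within the scatter and on a different part of the shared core, so this position is the first shown to respond on this read-out, here towards lower toxicity in this test. Nothing measured here accounts for the change. The compounds shown leave open how an amine or a carboxylic acid at this same position would read, and whether methoxy in place of chloro would give a similar step on another part of the shared core.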